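Shifting the Pyridyl Nitrogen: From Compound 2 to Compound 3

The compounds below may be only part of what the source reports. "The series", "measured", "known", "first", "only" and "open" are said of these compounds alone.

Compound 1 `N#Cc1ccc(-c2csc(N/N=C\c3ccncc3)n2)cc1`: "not active" (no number reported) in an in vitro assay on BTI-TN-5B1-4 cells for inhibition of Amine oxidase [flavin-containing] A (Homo sapiens), read by Amplex Red, with a stated time of 15 min, tested at 100 uM; a higher number here means more inhibition at the concentration tested (going by the name of the read-out), a lower number less inhibition
Compound 2 `Fc1ccc(-c2csc(N/N=C\c3cccnc3)n2)cc1`: 40% in this assay

For the measured compounds named here, compound 2 holds the only number reported in this assay; compound 1 was reported as not active, without a number, so it cannot be ranked against compound 2 in any precise way. Compound 3 `Fc1ccc(-c2csc(N/N=C\c3ccncc3)n2)cc1` has the same atoms as compound 2, joined differently: pyridin-4-yl in place of pyridin-3-yl on a carbon with a double bond to nitrogen. Going by the values given here, no measured pair differs by this change alone, so the size of the step cannot be read from the data. Among the compounds with values here, the only hint is that compound 1, which also carries pyridin-4-yl but bears a nitrile where compound 2 and compound 3 bear fluorine, was reported as not active in this assay; since compound 1 also differs in that second place, this is suggestive rather than decisive. The step from compound 2 to compound 3 is expected to be a decrease of a number 18 percentage points lower from compound 2 to compound 3 (beyond the scatter), somewhat beyond the scatter but uncertain. Compound 3 is expected to give 22% in this assay, with a range from 5% to 48%.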

Compound 3, a percentage reported as inhibition, at one concentration (the size of the read-out at that concentration, not a potency): 40%
Compound 3: the middle estimate sits 18 percentage points below what was measured; the measured number falls inside the stated range.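

In this assay, putting pyridin-4-yl in place of pyridin-3-yl on a carbon with a double bond to nitrogen gives no change at the digits printed from compound 2 to compound 3 (within the scatter), and this is the first pair among these compounds that differs in one place only. At this one concentration, the two pyridyl groups cannot be told apart, and pyridin-4-yl clearly allows a measurable reading. For the compounds shown here, that weakens the link between this group and the result for compound 1 , which carries the same pyridin-4-yl but a nitrile where compound 3 has fluorine: compound 1 gives "not active" (no number reported), so no step to it can be read, and the nitrile remains the one structural difference between the two. No measurement shown here explains why compound 2 and compound 3 read alike.

Still open, from the compounds shown here alone, is whether pyridin-2-yl or a plain phenyl ring on the same carbon would give a similar reading. It is also unclear how a chlorine or methoxy group in place of the fluorine would behave, and a reading at one concentration gives no potency for any of these compounds.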